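This account rests on a few compounds, and the source may have more. Where it says the series, first, only, none or still open, it means among the compounds named here.

In a functional assay on FM3A cells (Mus musculus) for antiproliferative activity (a higher number here means a weaker inhibitor, a lower number a stronger inhibitor), compound 1 (`COc1cc(C(=O)c2sc(-c3ccc(Br)cc3)cc2N)cc(OC)c1OC`) gives 150 nM, compound 2 (`COc1cc(C(=O)c2sc(-c3ccc(Cl)cc3)cc2N)cc(OC)c1OC`) gives 90 nM and compound 3 (`COc1cc(C(=O)c2sc(-c3ccncc3)cc2N)cc(OC)c1OC`) gives 150 nM. Compound 3 is thus level with compound 1, and all three lie within the usual scatter of one another. Compound 4 (`COc1cc(C(=O)c2sc(-c3ccc(C)cc3)cc2N)cc(OC)c1OC`) carries 4-methylphenyl in place of pyridin-4-yl on an aromatic carbon. Among the measured compounds shown here, two measured steps bear on this, since each exchanges a substituted phenyl ring for pyridin-4-yl: no change at the digits printed from compound 1 to compound 3 (within the scatter) and a 1.7-fold higher number from compound 2 to compound 3 (0.22 log units; within the scatter). Neither goes beyond the scatter, so no step beyond the scatter is expected in this assay when a substituted phenyl ring returns. The expected step is a 1.4-fold lower number from compound 3 to compound 4 (0.13 log units; within the scatter). Compound 4 is estimated at 110 nM, with a range from 45 nM to 280 nM.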

Compound 4, half-maximal inhibitory concentration: 16 nM
For compound 4 the middle estimate is 6.9-fold (0.84 log units) above the measured one, and the stated range ends above it.
By their numbers in this assay, from the lowest: compound 4; then compounds 2, 1 and 3 (each within the scatter of the next).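

In this assay, this position, on the ring carbon next to the ring sulfur, can shift the number beyond the scatter after all: 4-methylphenyl in place of pyridin-4-yl gives a 9.4-fold lower number from compound 3 to compound 4 (0.97 log units; beyond the scatter). The group on the phenyl ring matters too, with methyl in place of chloro giving a 5.6-fold lower number from compound 2 to compound 4 (0.75 log units; beyond the scatter) and methyl in place of bromo giving a 9.4-fold lower number from compound 1 to compound 4 (0.97 log units; beyond the scatter). Nothing available here accounts for methyl standing apart. Still open, going by these compounds, is whether an ethyl, a methoxy or an amine at that spot on the phenyl ring would match methyl.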